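The source may report more compounds than this note shows. Statements on the series, on what has been measured and on what is new or still open speak of the compounds shown alone.

Measured compounds and their values:

Compound 1, `CNc1ccc2[nH]nc(C(=O)O)c2c1` — in an assay on isolated protein for inhibition of 2-Hydroxyacid oxidase 1 (Homo sapiens), with stated times of 30 min and 15 min (a higher number here means a weaker inhibitor, a lower number a stronger inhibitor), compound 1 gives > 30000 nM
Compound 2, `Cc1csc(-c2cccc(CNc3ccc4[nH]nc(C(=O)O)c4c3)c2O)n1` — in this assay compound 2 gives 23 nM

The value for compound 1 is a limit of the assay, not a measured number. Within the data shown here, compound 2 therefore stands as the only real number in this set, while the single other entry is a limit (the limit of > 30000 nM in this assay, at which 1 of the 2 values shown sits). Beside these two sits compound 3, `Cc1nc(-c2cccc(CNc3ccc4[nH]nc(C(=O)O)c4c3)c2O)sc1C`, which has not yet been measured. It differs from compound 2 in one place: methyl in place of hydrogen on an aromatic carbon. Among the measured compounds shown here, no pair of measured compounds differs by a change of this kind, so the step between them has to be judged without a direct precedent. Adding one methyl to the five-membered ring that already carries a methyl is a small change, and the expectation is that it shifts the number by no more than the usual scatter in either direction. Compound 3 is thus expected to give about 25 nM, with a likely range from 8 nM to 80 nM. The step this estimate implies is a 1.1-fold higher number from compound 2 to compound 3 (0.04 log units; within the scatter), which is expected to be no real change.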

Compound 3, half-maximal inhibitory concentration in the 2-Hydroxyacid oxidase 1 assay: 25 nM
Compound 3: middle estimate and measured number agree at the digits printed; the range from low to high includes it.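

In the 2-Hydroxyacid oxidase 1 assay, adding the methyl gives a 1.1-fold higher number from compound 2 to compound 3 (0.04 log units; within the scatter), so the ring carbon next to the ring sulfur accepts this extra group with no real change in the number. In a physicochemical assay for solubility, measured as kinetic solubility, at pH 2 (on this read-out higher numbers stand for higher solubility and lower numbers for lower solubility), compound 2 gives 5000 nM, and compound 3 gives 20000 nM. Among these compounds, the same change does register in the physicochemical assay, where the difference is modest but beyond the usual scatter, so the 4,5-dimethyl-1,3-thiazol-2-yl group gives a measured gain in solubility: the measured solubility of compound 2, 5000 nM, and of compound 3, 20000 nM, a 4.0-fold higher number (0.60 log units; beyond the scatter) Until this pair, no step between two measured compounds could be read, and it now shows that one small change at this position can leave enzyme inhibition in place while solubility moves.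

From the compounds shown here alone, only methyl and hydrogen have been seen at this position, so it remains open whether a larger or different group, such as an ethyl group or a methoxy group, would be accepted as well. A single pair also cannot tell whether the step in the physicochemical assay would recur if the same methyl were added to a different compound.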